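Amide aryl exchange and cytotoxicity toward colon epithelial cells

The compounds below may be only part of what the source reports. "The series", "measured", "known", "first", "only" and "open" are said of these compounds alone.

Compound 1, `O=C(Nc1ccc(OC(F)F)cc1)c1cccc(/C=C2\CC(=O)N(c3ccccc3)C2=O)c1`: > 100000 nM
Compound 2, `COc1ccc(NC(=O)c2cccc(/C=C3\CC(=O)N(c4ccccc4)C3=O)c2)c(C)c1`: > 100000 nM

Of the compounds shown here, two on a shared core have been tested in an ADME assay on NCM460 cells (Homo sapiens) for cytotoxicity, read by MTT assay, with a stated time of 72 h; on this read-out higher numbers stand for weaker inhibition and lower numbers for stronger inhibition. Compound 1 `O=C(Nc1ccc(OC(F)F)cc1)c1cccc(/C=C2\CC(=O)N(c3ccccc3)C2=O)c1` returns only a limit of the assay, > 100000 nM. Compound 2 `COc1ccc(NC(=O)c2cccc(/C=C3\CC(=O)N(c4ccccc4)C3=O)c2)c(C)c1` likewise returns a limit and not a number, > 100000 nM. Both readings come from the limit of > 100000 nM in this assay, at which 2 of the 2 values shown sit, so the step that the two limits leave unreadable from compound 1 to compound 2 cannot be read in either direction. On the numbers shown, compound 2 therefore stands at the limit of this assay, with no measured value beneath it.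

The change now followed is 2,5-dimethoxyphenyl in place of 4-methoxy-2-methylphenyl on an amide-type nitrogen, which gives compound 3 `COc1ccc(OC)c(NC(=O)c2cccc(/C=C3\CC(=O)N(c4ccccc4)C3=O)c2)c1`. Within the data shown here, the single measured step, a step that the two limits leave unreadable from compound 1 to compound 2, also exchanged the aryl group on the amide-type nitrogen, and its size is not readable, so it supports no expectation of a step beyond the scatter. Compound 3 is consequently expected to stay at the limit of this assay. The step is estimated as a step that the limit leaves unreadable from compound 2 to compound 3. The estimated value for compound 3 is 150000 nM, expected to fall between 40000 nM and 600000 nM.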

Compound 3, half-maximal inhibitory concentration: > 100000 nM
Compound 3 gave a limit, no number; the forecaster's own chance of this, stated with the estimate: 80%; the middle value is on the limit's open side.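

Compound 3 also returns only a limit of the assay, > 100000 nM, in this assay. No step among compound 1, compound 2 and compound 3 can be read, because all three readings rest on the same limit: the limit of > 100000 nM in this assay, at which 3 of the 3 values shown sit.

The compounds shown leave open how these three aryl groups on the amide-type nitrogen rank against one another in this assay.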